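The source may report more compounds than this note shows. Statements on the series, on what has been measured and on what is new or still open speak of the compounds shown alone.

Among the compounds with values here, in a functional assay on A-375 cells (Homo sapiens) for antiproliferative activity, read by MTT assay, with a stated time of 24 h (a higher number here means a weaker inhibitor, a lower number a stronger inhibitor), compound 1 `C#CCOc1ccc2c(=O)c(-c3cc(OC)c(OC)cc3OC)coc2c1` gives 3680 nM, the only actual number so far. Compound 2 `COc1cccc(C(=O)Oc2ccc3c(=O)c(-c4cc(OC)c(OC)cc4OC)coc3c2)c1` reads > 10000 nM, which is a limit of the assay. Compound 3 `COc1cc(OC)c(-c2coc3cc(OCc4ccc(F)cc4)ccc3c2=O)cc1OC` keeps the core of compound 1 and changes only the ether group, propargyl to 4-fluorobenzyl: 4-fluorophenyl in place of ethynyl on a saturated chain carbon bound to an oxygen on an aromatic ring. Within the data shown here, one measured step bears on this, an at least 2.7-fold higher number from compound 1 to compound 2 (0.43 log units; beyond the scatter), which also replaces propargyl and is bounded only from one side. A modest move to a weaker number is therefore expected, a 1.6-fold higher number from compound 1 to compound 3 (0.21 log units; within the scatter), though that single step is a loose guide. Compound 3 is estimated at 6000 nM, within a range of 2000 nM to 18000 nM.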

Compound 3, half-maximal inhibitory concentration: 1720 nM
The estimate for compound 3 lay 3.5-fold (0.54 log units) above the measured number; measured number below the stated range.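

In this assay, this ether position proves able to move the number down as well as up, with a 2.1-fold lower number from compound 1 to compound 3 (0.33 log units; beyond the scatter). 4-fluorobenzyl and (3-methoxyphenyl)carbonyl both carry an aromatic ring, yet the record shows an at least 5.8-fold lower number from compound 2 to compound 3 (0.76 log units; beyond the scatter), so a ring on this oxygen does not by itself weaken the compound. That step is open on one side, compound 2 standing at a limit: the limit of > 10000 nM in this assay, at which 1 of the 3 values shown sits.

Going by these compounds, whether the lower number belongs to the fluorine or to the benzyl ring stays open. So does how a plain benzyl, a longer chain or an amine would read on this oxygen.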